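Chloro for fluoro on a sulfonyl-bearing aryl core

The source may report more compounds than this note shows. Statements on the series, on what has been measured and on what is new or still open speak of the compounds shown alone.

Measured compounds:
compound 1 `CS(=O)(=O)c1cc(F)ccc1NCC1=NCCN1`, 661 nM
compound 2 `CSc1ccc(F)cc1NCC1=NCCN1`, 33.1 nM
compound 3 `CSc1ccc(Cl)cc1NCC1=NCCN1`, 18.6 nM

Of the compounds shown here, three have been tested in an assay for binding affinity to Alpha-1A adrenergic receptor (Homo sapiens), read by radioligand binding; on this read-out higher numbers stand for weaker inhibition and lower numbers for stronger inhibition. Compound 1 `CS(=O)(=O)c1cc(F)ccc1NCC1=NCCN1` gives 661 nM in this assay, the highest of the three numbers. Compound 2 `CSc1ccc(F)cc1NCC1=NCCN1` gives 33.1 nM, and compound 3 `CSc1ccc(Cl)cc1NCC1=NCCN1` gives 18.6 nM. The difference between the core of compound 1 and that of compound 2 is not broken down here.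

Compound 2 and compound 3 differ in one place, (chloro in place of fluoro on an aromatic carbon), and this change gave a 1.8-fold lower number from compound 2 to compound 3 (0.25 log units; within the scatter). The unmeasured compound 4 `CS(=O)(=O)c1cc(Cl)ccc1NCC1=NCCN1` stands to compound 1 as compound 3 stands to compound 2: chloro in place of fluoro on an aromatic carbon. The two places are not the same word for word: in compound 2 the halogen sits meta to a group of 7 heavy atoms and para to a methylsulfanyl group, whereas in compound 1 it sits meta to a methylsulfonyl group and para to a group of 7 heavy atoms. It is therefore the same kind of change, not the same change.

Because the step from compound 2 to compound 3 was a 1.8-fold lower number from compound 2 to compound 3 (0.25 log units; within the scatter), a step of similar size is expected for compound 4, namely a 1.8-fold lower number from compound 1 to compound 4 (0.25 log units; within the scatter) in this assay, though the different surroundings leave room for a larger or smaller move. Compound 4 is estimated to give about 370 nM, with a likely range from 150 nM to 900 nM.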

Compound 4, inhibition constant: 457 nM
For compound 4 the middle estimate is 1.2-fold (0.09 log units) below the measured one; the range from low to high includes it.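

In this assay, chloro in place of fluoro on the core of compound 1 gave a 1.4-fold lower number from compound 1 to compound 4 (0.16 log units; within the scatter), so on this core the swap moves the number no further than repeat measurements could. Set side by side, the two steps agree, which means that in these four compounds the change carried from one core to the other with no detectable difference, even though the halogen has different surroundings on the two cores: the same change on two cores in this assay, a 1.8-fold lower number (0.25 log units; within the scatter) from compound 2 to compound 3 and a 1.4-fold lower number (0.16 log units; within the scatter) from compound 1 to compound 4, 1.2-fold (0.09 log units) apart, within the scatter of two such steps. This does not show that chloro truly binds better or worse than fluoro on either core, since neither step rises above the scatter, and agreement between two small steps on two cores says little about a third core or about a change with a larger effect.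

As far as these compounds go, only fluoro and chloro appear at this place, so it remains open what bromo, a methoxy group or a nitrile would do there, and whether such a step would also carry from one core to the other. The core of compound 1 and the core of compound 2 also differ in more than one place, which leaves open what the methylsulfonyl group alone contributes.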